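Changing the halogenated ring on the sulfur of compound 2

The source may report more compounds than this note shows. Statements on the series, on what has been measured and on what is new or still open speak of the compounds shown alone.

Compound 1 `Cc1cc(C)c(SCc2ncnc3c2ncn3[C@@H]2O[C@H](CO)[C@@H](O)[C@H]2O)c(C)c1`: 33100 nM
Compound 2 `OC[C@H]1O[C@@H](n2cnc3c(CSc4ccccc4Br)ncnc32)[C@H](O)[C@@H]1O`: 2400 nM

In an assay on isolated protein for binding affinity to Equilibrative nucleoside transporter 1 (Homo sapiens) (on this read-out lower numbers stand for stronger inhibition and higher numbers for weaker inhibition), compound 2 stands lowest of the two numbers, with compound 1 the nearest. Among the measured compounds shown here, the one measured step, a 14-fold lower number from compound 1 to compound 2 (1.14 log units; beyond the scatter), came from exchanging a ring carrying three methyl groups for the bromophenyl. Compound 3 `OC[C@H]1O[C@@H](n2cnc3c(CSc4c(F)cccc4Cl)ncnc32)[C@H](O)[C@@H]1O` differs from compound 2 by 2-chloro-6-fluorophenyl in place of 2-bromophenyl on a sulfur. For the measured compounds named here, no measured step covers a 2-chloro-6-fluorophenyl, so that step bears only loosely here. Compound 3 is therefore expected to stay near compound 2, a step of a 1.5-fold higher number from compound 2 to compound 3 (0.16 log units; within the scatter), with an estimate of 3500 nM and a range from 1000 nM to 12000 nM.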

Compound 3, half-maximal inhibitory concentration: 1510 nM
Compound 3: middle estimate off by 2.3-fold (0.37 log units), on the high side, within the range that was stated.
By their numbers in this assay, from the lowest: compounds 3 and 2 (each within the scatter of the next); then compound 1.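

On the sulfur, 2-chloro-6-fluorophenyl and 2-bromophenyl cannot be told apart in this assay, with a 1.6-fold lower number from compound 2 to compound 3 (0.20 log units; within the scatter), so a different halogen pattern on the ring leaves the number where it was. Set against the 2,4,6-trimethylphenyl ring, the new ring gives a 22-fold lower number from compound 1 to compound 3 (1.34 log units; beyond the scatter), which means that both halogen-bearing rings stand clear of compound 1. No measured evidence bears on the reason for this gap.

On these data alone, it remains open whether plain phenyl, without any halogen, would stay at this level. As far as these compounds go, a ring carrying an amine or a carboxylic acid, or a benzyl group on the sulfur, is equally open.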